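Swapping one chloro for hydrogen in a cytotoxic compound

The source may hold more compounds than are shown below. What is called first, only, known or untested is meant among the compounds shown, and "the series" means these compounds.

In a functional assay on SK-N-SH cells (Homo sapiens) for cytotoxicity, read by MTT assay, with a stated time of 48 h (on this read-out lower numbers stand for stronger inhibition and higher numbers for weaker inhibition), compound 1 (`O=C1Nc2ccc(Cl)cc2C1(c1c[nH]c2ccc(Br)cc12)c1c[nH]c2ccc(Br)cc12`) gives 1040 nM and compound 2 (`N#Cc1ccc2[nH]cc(C3(c4c[nH]c5ccc(C#N)cc45)C(=O)Nc4ccccc43)c2c1`) gives 940 nM as its value. Among the measured compounds shown here, these two numbers lie within the usual scatter of each other, so compound 1 stands level with the only other compound measured so far. Compound 3 (`O=C1Nc2ccccc2C1(c1c[nH]c2ccc(Br)cc12)c1c[nH]c2ccc(Br)cc12`) is still unmeasured. It comes from compound 1 by one small edit (hydrogen in place of chloro on an aromatic carbon), which puts hydrogen in place of chloro on an aromatic carbon. For the measured compounds named here, no measured pair differs in just one place, so the data hold no direct measure of this swap. The closest guide is how near the two measured numbers sit. With compound 1 at 1040 nM and compound 2 at 940 nM in this assay as the only reference points, no step beyond the scatter is expected, and neither direction is favoured. The expected step is a 1.0-fold lower number from compound 1 to compound 3 (0.02 log units; within the scatter) and that stays within the scatter. For compound 3 the estimated value is 1000 nM with an expected range from 450 nM to 2200 nM in repeated measurements.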

Compound 3, half-maximal inhibitory concentration: 930 nM
Beside the measured number, compound 3's estimate is 1.1-fold (0.03 log units) above it, and the stated range covers the measured number.
By their numbers in this assay, from the lowest: compounds 3, 2 and 1 (each within the scatter of the next).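

In this assay, among the compounds shown here, the swap gives a 1.1-fold lower number from compound 1 to compound 3 (0.05 log units; within the scatter) and so offers the first direct reading of a single change in this set, since the earlier pair differed in more than one place. At this position, on an aromatic carbon of a six-membered aromatic ring of carbon only, the chloro can give way to hydrogen with no step beyond the scatter, so this cytotoxic read-out does not depend on the chloro here. No separate measurement bears on why the two compounds sit level, so the result stands as an observation without an explanation.

Going by these compounds, it remains open whether this position stays just as quiet with a different kind of group on the same aromatic carbon, such as a methoxy group, an amine or a carboxylic acid, any of which would test it more sharply than hydrogen does. Whether the chloro-to-hydrogen swap would read the same with nitrile in place of the bromo groups, the nitrile being what compound 2 carries, is open too.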